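The compounds below may be only part of what the source reports. "The series", "measured", "known", "first", "only" and "open" are said of these compounds alone.

Within the data shown here, in a functional assay on PC-9 cells (Homo sapiens) for inhibition, read by MTT assay, with a stated time of 72 h (on this read-out higher numbers stand for weaker inhibition and lower numbers for stronger inhibition), compound 2 `Cc1cc(Nc2cc(-c3ccccc3)[nH]n2)n2nc(SCc3nc4ccccc4[nH]3)nc2n1` gives 4840 nM, the only actual number so far. Compound 1 `C#CCSc1nc2nc(C)cc(Nc3cc(-c4ccccc4)[nH]n3)n2n1` gives > 50000 nM, which is a limit of the assay (the limit of > 50000 nM in this assay, at which 1 of the 2 values shown sits). Compound 3 `Cc1cc(Nc2cc(-c3ccccc3)[nH]n2)n2nc(SCC3CC3)nc2n1` carries cyclopropyl in place of 1H-benzimidazol-2-yl on a saturated chain carbon bound to a sulfur. Among the measured compounds shown here, one measured step bears on this: an at least 10-fold lower number from compound 1 to compound 2 (1.01 log units; beyond the scatter), a large change that came with the arrival of the group now leaving. A sizeable move to a higher number is therefore expected, a 6.2-fold higher number from compound 2 to compound 3 (0.79 log units; beyond the scatter). For compound 3 the estimated value is 30000 nM, with an expected range of 10000 nM to 50000 nM.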

Compound 3, half-maximal inhibitory concentration: > 50000 nM
Compound 3: no number, only a limit; the forecaster's own chance of this, stated with the estimate: 45%; at least 1.6-fold (0.22 log units) between middle value and limit.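

With cyclopropyl in place of 1H-benzimidazol-2-yl on a saturated chain carbon bound to a sulfur, this assay shows an at least 10-fold higher number from compound 2 to compound 3 (1.01 log units; beyond the scatter). The earlier loss with ethynyl is thus repeated with a second group, and among these three compounds only the 1H-benzimidazol-2-yl group gives an actual number. The value of compound 3 is a limit, so the step between compound 1 and compound 3 cannot be read: the limit of > 50000 nM in this assay, at which 2 of the 3 values shown sit.

On these data alone, whether phenyl or 1H-imidazol-2-yl at this place would also give an actual number stays open. So does how far past the limit compound 1 and compound 3 lie.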